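The compounds below may be only part of what the source reports. "The series", "measured", "known", "first", "only" and "open" are said of these compounds alone.

Of the compounds shown here, three built on one shared core have been measured in a functional assay on HUVEC cells (Homo sapiens), read by fluorescence and microscopy, with a stated time of 6 h, tested at 250 nM; a lower number here means a stronger effect, a higher number a weaker effect of the compound at the concentration tested. Compound 1 `N#Cc1c(Nc2ccc(C(F)(F)F)cc2)sc2ccccc12` gives 65%, compound 2 `N#Cc1c(Nc2ccc([N+](=O)[O-])cc2)sc2ccccc12` gives 37%, and compound 3 `N#Cc1c(Nc2cccc(O)c2)sc2ccccc12` gives 60%. Compound 2 thus stands lowest of the three, beyond the scatter against both others, which in this assay means the strongest effect. Among the measured compounds shown here, the only step between close relatives, a number 28 percentage points lower from compound 1 to compound 2 (beyond the scatter), shows that changing this one group alone can move the read-out well beyond the scatter. Compound 4 `N#Cc1c(Nc2ccc(N)cc2)sc2ccccc12` differs from compound 2 by amino in place of nitro on an aromatic carbon. For the measured compounds named here, no measured pair swaps nitro for amino, so that single step is the only guide. A modest move back toward the numbers of compound 1 and compound 3 is expected, with an estimated step of a number 18 percentage points higher from compound 2 to compound 4 (beyond the scatter). Compound 4 is therefore estimated at 55%, in a range from 35% to 75%.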

Compound 4, a percentage reported as activity, at one concentration (the size of the read-out at that concentration, not a potency): 51%
The estimate for compound 4 lay 4 percentage points above the measured number; the range from low to high includes it.
By their numbers in this assay, from the lowest: compound 2; then compounds 4, 3 and 1 (each within the scatter of the next, the first and the last beyond it).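

At this carbon, para to a large group, the read-out in this assay now separates three groups rather than two: amino for nitro gives a number 14 percentage points higher from compound 2 to compound 4 (beyond the scatter), while amino for trifluoromethyl gives a number 14 percentage points lower from compound 1 to compound 4 (beyond the scatter). Amino thus falls between the other two groups, apart from each. No measurement shown here explains this order.

Where a carboxylic acid or a methoxy group on this same carbon would fall remains open. So does whether a longer chain on the amino nitrogen would keep its place in this order.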